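Ester replacement in the piperidinyl dithiocarbamate series

This account rests on a few compounds, and the source may have more. Where it says the series, first, only, none or still open, it means among the compounds named here.

The series shares a nitroimidazole dithiocarbamate core. In an ADME assay on HeLa cells (Homo sapiens) for cytotoxicity (a lower number here means a stronger inhibitor, a higher number a weaker inhibitor), compound 1 `Cc1ncc([N+](=O)[O-])n1CCSC(=S)N1CCC2(CC1)OCCO2` gives > 1000 ug/mL, which is a limit of the assay. Compound 2 `Cc1ncc([N+](=O)[O-])n1CCSC(=S)N1CCC(OC(=O)C(Cl)Cl)CC1` gives > 1000 ug/mL in this assay, again a limit rather than a number. Compound 3 `Cc1ncc([N+](=O)[O-])n1CCSC(=S)N1CCC(O)CC1` gives 930 ug/mL in this assay. Among the compounds with values here, the step of an at least 1.0-fold lower number from compound 2 to compound 3 (0.03 log units; that floor lies within the scatter) is the only measured change at the ester oxygen, and its floor sits within the scatter. Compound 2 therefore stands only as a limit, and the limit of > 1000 ug/mL in this assay, at which 2 of the 3 values shown sit, describes where most of the series sits.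

Compound 4 `Cc1ncc([N+](=O)[O-])n1CCSC(=S)N1CCC(OC(=O)CSC(=S)N2CCCC2)CC1` differs from compound 2 by a group of 9 heavy atoms (6 carbon, 1 nitrogen, 2 sulfur; one five-membered non-aromatic ring with 1 hetero atom) in place of a group of 3 heavy atoms (1 carbon, 2 chlorine; no ring), on a carbonyl carbon. Within the data shown here, the single step that bears on this carbonyl position, from compound 2 to compound 3, showed no change beyond the scatter, so no step beyond the scatter is expected here either, in either direction. The expected step of a number no higher from compound 2 to compound 4 (the limit leaves the size open) is accordingly flat. Compound 4 is estimated at 1000 ug/mL, with a range from 500 ug/mL to 2000 ug/mL, and most likely reports again as a limit.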

Compound 4, half-maximal inhibitory concentration: > 1000 ug/mL
Compound 4: no number, only a limit (the forecaster's own chance of this, stated with the estimate: 70%); the middle value lies on the limit itself.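

Within the data shown here, compound 4 gives only a limit in this assay, as compound 2 does, so no step between compound 2 and compound 4 can be read. Still open is whether any group on this carbonyl carbon moves the read-out beyond the scatter, with most of the series at one point: the limit of > 1000 ug/mL in this assay, at which 3 of the 4 values shown sit.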